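This account rests on a few compounds, and the source may have more. Where it says the series, first, only, none or still open, it means among the compounds named here.

Measured in an assay on cells for positive allosteric modulation of Cystic fibrosis transmembrane conductance regulator variant F508del (Homo sapiens), with stated times of 10 min and 7 s, in the presence of a further agent that is not named here; a higher number here means that more compound is needed for the effect, a lower number that less compound is needed:

compound 1, `Cc1ccc(C(=O)Nc2sc3c(c2C(N)=O)CCCC3)s1`: 652 nM
compound 2, `CC1(C)Cc2c(sc(NC(=O)c3ccccc3O)c2C(N)=O)CO1`: 13 nM
compound 3, `CC1(C)Cc2c(sc(NC(=O)c3ccn[nH]3)c2C(N)=O)C(C)(C)O1`: 3 nM

Among these three, compound 3 stands at the lowest number, so the least compound is needed for the effect. Compound 2 is its nearest neighbour, and compound 1 lies furthest away; both gaps are wider than the usual scatter of repeated measurements, so compound 3 can be called the most potent of the three. All three share an amide attached to the same kind of thiophene-carrying core, and they differ in the group that sits on the carbonyl carbon of that amide.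

The next compound, compound 4, `CC1(C)Cc2c(sc(NC(=O)C3(CO)CC3)c2C(N)=O)C(C)(C)O1`, is not yet measured. Compared with compound 3, the change is 1-(hydroxymethyl)cyclopropyl in place of 1H-pyrazol-5-yl on a carbonyl carbon. Put simply, an aromatic five-membered ring is exchanged for a small saturated ring carrying a hydroxymethyl arm, while the count of hydrogen-bond donors and acceptors stays the same.

Among the measured compounds shown here, no pair among the measured compounds isolates this kind of exchange, so the expectation rests on the general picture alone. The step from compound 3 to compound 4 is expected to raise the number by a moderate amount, a 10-fold higher number from compound 3 to compound 4 (1.00 log units; beyond the scatter), beyond the scatter but well short of the gap to compound 1. Compound 4 is therefore estimated at 30 nM, within a range from 5 nM to 200 nM.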

Compound 4, half-maximal effective concentration: 15 nM
For compound 4 the middle estimate is 2.0-fold (0.30 log units) above the measured one; the range from low to high includes it.
By their numbers in this assay, from the lowest: compound 3; then compounds 2 and 4 (each within the scatter of the next); then compound 1.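

Among the compounds shown here, compounds 3 and 4 are the first pair here that differ in only one place, so the group on the carbonyl carbon can now be judged on its own, with the shared core held constant. In this assay, the exchange of 1H-pyrazol-5-yl for 1-(hydroxymethyl)cyclopropyl gives a 5.0-fold higher number from compound 3 to compound 4 (0.70 log units; beyond the scatter), so this position accepts a non-aromatic ring at a modest cost, with compound 4 still at 15 nM, even though the two groups match in their counts of heavy atoms, hydrogen-bond donors and hydrogen-bond acceptors. No measurement at hand explains why the number rises.

The compounds shown leave open which part of the new group matters, since the cyclopropyl ring and its hydroxymethyl arm always appear together here, and a plain cyclopropyl, a longer hydroxyalkyl chain, or an amine or a carboxylic acid in place of the hydroxyl would separate those parts. They also leave open whether the same exchange would cost a similar amount on a different core.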